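Chloro-bearing acid analogue in the writhing test

The compounds below may be only part of what the source reports. "The series", "measured", "known", "first", "only" and "open" are said of these compounds alone.

Compound 1 `O=C(O)[C@H]1CCC[C@@H](c2ccc3ccccc3c2)O1`: 43.1%
Compound 2 `OC[C@H]1CCC[C@@H](c2cccc3ccccc23)O1`: 39.2%
Compound 3 `CC(C)C(=O)OC[C@H]1C[C@@H](Cl)C[C@@H](c2ccc3ccccc3c2)O1`: 44.4%

The three compounds were examined in a functional assay on the whole organism (Abdomen, strain Swiss albino) for inhibition, with Mus musculus as the target, in the writhing test, with a stated time of 30 min, at a dose of 30 mg/kg by the oral route; on this read-out lower numbers stand for less inhibition and higher numbers for more inhibition at the one dose given (going by the name of the read-out). Compound 3 gives 44.4%, and the values of compound 1 and compound 2 both lie within the usual scatter of that number, so none of the three can be told apart from the others on this read-out.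

Compound 4 `O=C(O)[C@H]1C[C@@H](Cl)C[C@@H](c2ccc3ccccc3c2)O1` differs from compound 3 in one place: carboxy in place of ((isopropylcarbonyl)oxy)methyl on a saturated ring carbon. Going by the values given here, no measured pair shows this kind of change, so its size is unknown; the step from compound 3 to compound 4 in this assay is expected to stay within the scatter, a number 1.4 percentage points lower from compound 3 to compound 4 (within the scatter). Compound 4 is therefore estimated to give 43%, with a range from 30% to 56%.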

Compound 4, a percentage reported as inhibition, in the whole organism at one dose (the size of the read-out at that dose, not a potency): 28.1%
Compound 4: middle estimate off by 14.9 percentage points, on the high side; measured number below the stated range.
By their numbers in this assay, from the lowest: compound 4; then compounds 2, 1 and 3 (each within the scatter of the next).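

On the saturated ring carbon next to the ring oxygen, the exchange of ((isopropylcarbonyl)oxy)methyl for carboxy, with the chloro group in place, matters in this assay: it gives a number 16.3 percentage points lower from compound 3 to compound 4 (beyond the scatter). The chloro group matters as well, since chloro in place of hydrogen on a saturated ring carbon, with carboxy present, gives a number 15 percentage points lower from compound 1 to compound 4 (beyond the scatter). Nothing at hand accounts for either step. From the compounds shown here alone, whether the chloro step would hold alongside ((isopropylcarbonyl)oxy)methyl stays open, as does how an amide or a primary amine on this carbon would read.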